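Ethoxy in place of ethylsulfanyl on compound 1

A few compounds are considered here, and "the series" means these few. Any claim that something is new, unique, unknown or untested is made for them only; others in the source may bear on it.

Measured in a functional assay on HL-60 cells (Homo sapiens) for inhibition, read by resazurin assay, with a stated time of 72 h (on this read-out higher numbers stand for weaker inhibition and lower numbers for stronger inhibition), so far:
- compound 1 `CCSc1ccc(C2C(Oc3ccccc3)C(=O)N2c2cc(OC)c(OC)c(OC)c2)cc1` gives (508 nM)
- compound 2 `CCSc1ccc(C2CC(=O)N2c2cc(OC)c(OC)c(OC)c2)cc1` gives (204 nM)

Compound 1 stands highest of the two numbers (508 nM). Compound 3 `CCOc1ccc(C2C(Oc3ccccc3)C(=O)N2c2cc(OC)c(OC)c(OC)c2)cc1` keeps the core of compound 1 and differs in one group (ethoxy in place of ethylsulfanyl on an aromatic carbon), with ethoxy in place of ethylsulfanyl on an aromatic carbon. Among the measured compounds shown here, the only measured step is a modest one at another place, hydrogen in place of phenoxy on a saturated ring carbon (a 2.5-fold lower number from compound 1 to compound 2 (0.40 log units; beyond the scatter)). For the measured compounds named here, it shows the size of change seen so far, but no measured step covers the present exchange. No step beyond the scatter is therefore expected in this assay, and the data favour no direction. The expected step is a 1.1-fold lower number from compound 1 to compound 3 (0.05 log units; within the scatter) and it stays small. For compound 3 the estimate is 450 nM, with an expected range of 150 nM to 1300 nM.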

Compound 3, half-maximal inhibitory concentration: 494 nM
For compound 3 the middle estimate is 1.1-fold (0.04 log units) below the measured one; low and high end bracket the measured number.
By their numbers in this assay, from the lowest: compound 2; then compounds 3 and 1 (each within the scatter of the next).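

In this assay, ethoxy in place of ethylsulfanyl on the aromatic carbon para to a large group, with the rest of the core of compound 1 kept, gives (a 1.0-fold lower number from compound 1 to compound 3 (0.01 log units; within the scatter)), so with phenoxy present, this read-out does not separate the sulfur-linked and oxygen-linked ethyl groups. Among the compounds shown here, this is the first reading at this position, as the earlier step concerned only the phenoxy place. No measurement at hand accounts for this result.

As far as these compounds go, whether ethoxy and ethylsulfanyl also match with hydrogen in place of phenoxy, as in compound 2, remains open. Also open, from the compounds shown here alone, is how far this position tolerates a group of another kind, such as an amine like dimethylamino, a carboxylic acid or a longer chain like butoxy.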